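Hydroxamate amides: branching the benzyl amide of compound 1

The source may report more compounds than this note shows. Statements on the series, on what has been measured and on what is new or still open speak of the compounds shown alone.

Compound 1 `CN(C)c1ccc(C(=O)N[C@@H](CCCCCC(=O)NO)C(=O)NCc2ccccc2)cc1` gives 1600 nM in a functional assay on MM96L cells (Homo sapiens) for antiproliferative activity (a higher number here means a weaker inhibitor, a lower number a stronger inhibitor), the highest of the three numbers in hand. Compound 2 `CN(C)c1ccc(C(=O)NC(CCCCCC(=O)NO)C(=O)NCc2ccccc2)cc1` gives 130 nM, and the step of a 12-fold lower number from compound 1 to compound 2 (1.09 log units; beyond the scatter) is large, due to the fact that one of compounds 1 and 2 is drawn with a defined configuration and the other without, at the place where they differ. Compound 3 `O=C(CCCCC[C@H](NC(=O)c1cc2c(Br)cccc2[nH]1)C(=O)NCc1ccccc1)NO` gives 490 nM, a modest step of a 3.3-fold lower number from compound 1 to compound 3 (0.51 log units; beyond the scatter). Compound 4 `CN(C)c1ccc(C(=O)N[C@@H](CCCCCC(=O)NO)C(=O)NC2(Cc3ccccc3)CCCC2)cc1` differs from compound 1 by 1-benzylcyclopentyl in place of benzyl on an amide-type nitrogen. Neither measured step touches the substituent on the amide nitrogen: one concerns the drawn configuration, the other the group on the carbonyl carbon. No step beyond the scatter is therefore expected, and the estimated step of no change at the digits printed from compound 1 to compound 4 (within the scatter) is set near no change with a wide range. For compound 4 the expected value is 1600 nM, between 500 nM and 5000 nM.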

Compound 4, half-maximal inhibitory concentration: 900 nM
For compound 4 the middle estimate is 1.8-fold (0.25 log units) above the measured one; low and high end bracket the measured number.
By their numbers in this assay, from the lowest: compound 2; then compounds 3, 4 and 1 (each within the scatter of the next, the first and the last beyond it).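

In this assay, the amide-type nitrogen accepts 1-benzylcyclopentyl in place of benzyl with a 1.8-fold lower number from compound 1 to compound 4 (0.25 log units; within the scatter), the first sign of how this position responds to change. Adding the five-membered carbon ring to the benzyl group thus produces no step beyond the scatter. Nothing at hand bears on the cause of this result.

From the compounds shown here alone, what an amine or a carboxylic acid on this nitrogen would give remains open. So does whether 1-benzylcyclopentyl would read the same alongside the 4-bromo-1H-indol-2-yl group of compound 3.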